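From methoxycarbonyl to ethoxycarbonyl on compound 3

The source may hold more compounds than are shown below. What is called first, only, known or untested is meant among the compounds shown, and "the series" means these compounds.

Among the compounds with values here, in a functional assay on HeLa cells (Homo sapiens) for antiproliferative activity, read by MTT assay, with a stated time of 48 h (on this read-out lower numbers stand for stronger inhibition of growth and higher numbers for weaker inhibition of growth), compound 3 (`COC(=O)N1N=C(c2cccc(O)c2)CC1c1cc(OC)c(OC)c(OC)c1`) gives 1970 nM, the lowest of the three numbers so far. Compound 4 (`CCOC(=O)N1N=C(c2cccc(O)c2)CC1c1cc(OC)c(OC)c(OC)c1`) has not been measured yet. It differs from compound 3 by methyl in place of hydrogen on a saturated chain carbon bound to an oxygen next to a carbonyl group, read as methoxycarbonyl to ethoxycarbonyl. Within the data shown here, no measured step covers this change. Among the measured compounds shown here, the only measured step, a 1.1-fold higher number from compound 1 to compound 2 (0.02 log units; within the scatter), is methoxy in place of hydrogen on an aromatic carbon, a different change, and says little here. Compound 1 (`CCOC(=O)N1N=C(c2ccccc2)CC1c1cc(OC)c(OC)c(OC)c1`) at 8230 nM and compound 2 (`CCOC(=O)N1N=C(c2ccc(OC)cc2)CC1c1cc(OC)c(OC)c(OC)c1`) at 8710 nM also carry ethoxycarbonyl but differ from compound 3 elsewhere too, so they support only a slight lean to a higher number. In this assay the expected change is a 1.3-fold higher number from compound 3 to compound 4 (0.10 log units; within the scatter), with no step beyond the scatter expected. For compound 4 the estimate is 2500 nM, with an expected range of 1000 nM to 6000 nM.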

Compound 4, concentration for 50% growth inhibition: 3280 nM
For compound 4 the middle estimate is 1.3-fold (0.12 log units) below the measured one; the measured number falls inside the stated range.
By their numbers in this assay, from the lowest: compounds 3 and 4 (each within the scatter of the next); then compounds 1 and 2 (each within the scatter of the next).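

Methyl in place of hydrogen at this saturated chain carbon gives in this assay a 1.7-fold higher number from compound 3 to compound 4 (0.22 log units; within the scatter) here, so the position accepts ethoxycarbonyl on this hydroxy-bearing compound. With ethoxycarbonyl held constant, hydroxy in place of hydrogen gives a 2.5-fold lower number from compound 1 to compound 4 (0.40 log units; beyond the scatter) and 3-hydroxyphenyl in place of 4-methoxyphenyl gives a 2.7-fold lower number from compound 2 to compound 4 (0.42 log units; beyond the scatter) as modest steps. No supporting data bear on the cause of these steps.

Open, on these data alone, is whether a longer chain such as propoxycarbonyl, or a carboxylic acid at this place, holds the number. Also open, as far as these compounds go, is how an amine in place of the hydroxy would read.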